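Swapping the Sulfonyl Aryl Group: From Compound 2 to Compound 3

The source may report more compounds than this note shows. Statements on the series, on what has been measured and on what is new or still open speak of the compounds shown alone.

In a functional assay (Cavia porcellus) with sulfonylurea receptors; K-ATP channels (Homo sapiens) as the target (on this read-out higher numbers stand for weaker inhibition and lower numbers for stronger inhibition), compound 2 `CC(O)(C(=O)Nc1ccc(S(=O)(=O)c2ccc(F)cc2)cc1)C(F)(F)F` gives 8600 nM, the highest number of the two measured here; compound 1 `CC(O)(C(=O)Nc1ccc(S(=O)(=O)c2ccccc2)c(F)c1)C(F)(F)F` gives 1800 nM, a gap beyond the usual scatter. Compound 3 `CC(O)(C(=O)Nc1ccc(S(=O)(=O)c2ccccc2Cl)cc1)C(F)(F)F` carries 2-chlorophenyl in place of 4-fluorophenyl on a sulfonyl sulfur. Among the measured compounds shown here, no measured pair differs in only this way, so the size of this move is unknown. Since compound 2 stands at 8600 nM while compound 1 sits lower, a modest drop in the number is expected, though it may stay within the scatter. Compound 3 is estimated at 5000 nM with a range of 1500 nM to 15000 nM. The expected step is a 1.7-fold lower number from compound 2 to compound 3 (0.24 log units; within the scatter).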

Compound 3, half-maximal inhibitory concentration: 2300 nM
Compound 3: the middle estimate sits 2.2-fold (0.34 log units) above what was measured; low and high end bracket the measured number.
By their numbers in this assay, from the lowest: compounds 1 and 3 (each within the scatter of the next); then compound 2.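

In this assay, the group on the sulfonyl sulfur proves able to shift the read-out on its own: 2-chlorophenyl in place of 4-fluorophenyl gives a 3.7-fold lower number from compound 2 to compound 3 (0.57 log units; beyond the scatter) with the rest of the molecule unchanged. Among the compounds shown here, this is the first measured step at this position, and it lies beyond the usual scatter. No measurement here explains why the number falls. Still open, going by these compounds, is whether the chlorine or its place on the ring matters more, which 2-fluorophenyl or 4-chlorophenyl could help separate. On these data alone, how a pyridine ring or a methoxyphenyl group would behave on the sulfonyl sulfur also remains open.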